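The source may report more compounds than this note shows. Statements on the series, on what has been measured and on what is new or still open speak of the compounds shown alone.

Going by the values given here, compound 1 `C=C1CCC[C@H]2[C@](C)(CC[C@]3(C)CC[C@@H]([C@@H](C)C(=O)O)OO3)[C@@H](C)CC[C@]12C` is the single compound of this set with a numerical reading: in a functional assay on SF-539 cells (Homo sapiens) for inhibition (on this read-out higher numbers stand for weaker inhibition of growth and lower numbers for stronger inhibition of growth), compound 1 gives 1070 nM. Among the compounds with values here, compound 2 `C=C1CCCC(C)(C)C1(O)CC/C(C)=C/CC[C@]1(C)CC[C@@H]([C@@H](C)C(=O)OC)OO1` is reported only at a limit of this assay, > 17500 nM, and that limit of > 17500 nM in this assay, at which 1 of the 2 values shown sits, is the one further value shown. Within the data shown here, the step of interest leads from compound 1 to compound 3 `C=C1CCC[C@H]2[C@](C)(CC[C@]3(C)CC[C@H]([C@@H](C)C(=O)O)OO3)[C@@H](C)CC[C@]12C`. the two compounds have the same atoms and bonds and differ only in configuration as drawn: 1 of 7 stereo elements differ; a stereocentre at a saturated ring carbon is drawn S in compound 1 and R in compound 3 No measured pair shows what such a change does in this assay. The two compounds share every atom and bond, so only a modest step is expected, and in the absence of any measured guide the expectation leans slightly towards weaker inhibition of growth, with a step of a 1.9-fold higher number from compound 1 to compound 3 (0.27 log units; within the scatter) expected. For compound 3 the estimate in this assay is 2000 nM, with a range from 500 nM to 10000 nM.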

Compound 3, concentration for 50% growth inhibition: 1610 nM
Beside the measured number, compound 3's estimate is 1.2-fold (0.09 log units) above it, within the range that was stated.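

In this assay, going by these compounds alone, the stereocentre at a saturated ring carbon gives the first step of this set that can be read, a 1.5-fold higher number from compound 1 to compound 3 (0.18 log units; within the scatter) and so drawing this carbon S or R leaves the two readings indistinguishable. With the carboxylic acid and the rest of the core held constant, this position shows no measurable dependence on its configuration as drawn. The step can be tied to that single carbon alone because of this: the fact that compounds 1 and 3 differ only in the configuration as drawn.

Compound 2 differs from both compounds in more than one place and is reported only at a limit, so it gives no readable step: the limit of > 17500 nM in this assay, at which 1 of the 3 values shown sits. Open remain whether the other stereo elements behave in the same way, and whether an amide in place of the carboxylic acid would keep the two configurations indistinguishable.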